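The source may report more compounds than this note shows. Statements on the series, on what has been measured and on what is new or still open speak of the compounds shown alone.

Measured compounds:
compound 1, `O=C1Nc2ccc(Br)cc2/C1=N/NC(=S)N1CCN(c2ccccc2)CC1`, 12300 nM;
compound 2, `O=C1Nc2ccc(Cl)cc2/C1=N/NC(=S)N1CCN(c2ccccc2)CC1`, 7340 nM;
compound 3, `O=C1Nc2cc(Br)ccc2/C1=N/NC(=S)N1CCN(c2ccccc2)CC1`, 15800 nM.

The three were tested in a functional assay on A549 cells (Homo sapiens) for inhibition, read by MTT assay, with a stated time of 72 h; on this read-out lower numbers stand for stronger inhibition and higher numbers for weaker inhibition. Compound 1 and compound 2 share a core and differ by chloro in place of bromo on an aromatic carbon; that change produced a 1.7-fold lower number from compound 1 to compound 2 (0.22 log units; within the scatter). Compound 3 carries the same atoms as compound 1, joined differently; the difference between the two cores is not broken down here. Compound 3 gives the highest number of the three; against compound 1 the gap is within the scatter, while against compound 2 it lies beyond it.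

Compound 4, `O=C1Nc2cc(Cl)ccc2/C1=N/NC(=S)N1CCN(c2ccccc2)CC1`, is not yet measured. It differs from compound 3 by chloro in place of bromo on an aromatic carbon, the same change as from compound 1 to compound 2. In this assay compound 4 is expected to show a 1.7-fold lower number from compound 3 to compound 4 (0.22 log units; within the scatter), a step of about the size seen in a 1.7-fold lower number from compound 1 to compound 2 (0.22 log units; within the scatter), because compound 3 gave 15800 nM and the earlier step was within the scatter. For compound 4 the estimate is 9500 nM, expected to fall between 5000 nM and 18000 nM.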

Compound 4, half-maximal inhibitory concentration: 27700 nM
Compound 4: middle estimate off by 2.9-fold (0.46 log units), on the low side, outside the stated range (above it).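

In this assay, chloro in place of bromo on an aromatic carbon gave a 1.8-fold higher number from compound 3 to compound 4 (0.24 log units; within the scatter), and set beside the same change on the core of compound 1, the two steps do not agree: the same change on two cores in this assay, a 1.7-fold lower number (0.22 log units; within the scatter) from compound 1 to compound 2 and a 1.8-fold higher number (0.24 log units; within the scatter) from compound 3 to compound 4, 2.9-fold (0.47 log units) apart, beyond the scatter of two such steps. This shows that, among these four compounds, the step seen on one core did not carry over to the other. It does not show why, each step alone stays within the scatter, and two pairs set no rule for the series.

The compounds shown leave open how an amine, a methoxy group or fluoro would behave in place of these halogens. As far as these compounds go, whether such groups would also give different steps on the two cores remains untested here.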